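A Benzyl Amide Variant and Its Expected Solubility

The compounds below may be only part of what the source reports. "The series", "measured", "known", "first", "only" and "open" are said of these compounds alone.

Within the data shown here, compound 1 `NC(=O)COc1ccc(OCCNCC(O)COc2ccccc2)cc1` carries an unsubstituted amide on the shared core, and in a physicochemical assay for solubility, at pH 7 (on this read-out higher numbers stand for higher solubility and lower numbers for lower solubility), compound 1 gives 400 ug/mL, the lowest of the two numbers measured so far. Its nearest neighbour is compound 2 `CCCNC(=O)COc1ccc(OCCNCC(O)COc2ccccc2)cc1`, which in this assay gives 600 ug/mL; the step of a 1.5-fold higher number from compound 1 to compound 2 (0.18 log units; within the scatter) lies within the scatter. Compound 3 `O=C(COc1ccc(OCCNCC(O)COc2ccccc2)cc1)NCc1ccccc1` is reached from compound 1 by benzyl in place of hydrogen on an amide-type nitrogen. Among the measured compounds shown here, only one measured step bears on this change, namely a 1.5-fold higher number from compound 1 to compound 2 (0.18 log units; within the scatter), and it shows that putting propyl on the amide nitrogen left the read-out essentially where it was. For the measured compounds named here, no measured step covers an aromatic group at this position, so the expectation is less firmly anchored; a modest downward step in this assay is nonetheless expected. Compound 3 is therefore expected to give 150 ug/mL in this assay, within a range from 50 ug/mL to 450 ug/mL. The expected step is thus a 2.7-fold lower number from compound 1 to compound 3 (0.43 log units; beyond the scatter).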

Compound 3, solubility: 40 ug/mL
Estimate against measurement, compound 3: 3.8-fold (0.57 log units) above; the whole stated range lies above it.
By their numbers in this assay, from the lowest: compound 3; then compounds 1 and 2 (each within the scatter of the next).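

At the amide-type nitrogen, the group that enters clearly matters in this assay: benzyl in place of hydrogen gives a drop beyond the scatter (a 10-fold lower number from compound 1 to compound 3 (1.00 log units; beyond the scatter)), which the propyl step had not shown. The drop also appears between the two substituted amides, where phenyl in place of ethyl on a saturated chain carbon bound to that nitrogen gives (a 15-fold lower number from compound 2 to compound 3 (1.18 log units; beyond the scatter)), so among these three compounds, replacing the amide hydrogen does not by itself set the read-out. Nothing available explains why the benzyl compound stands so far from the other two.

From the compounds shown here alone, it remains open whether the aromatic ring must be present for such a drop, which a cyclohexylmethyl group or a longer alkyl chain on the same nitrogen could test. Going by these compounds, how a phenyl group directly on that nitrogen, or a phenethyl group, would read out also stays unknown.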